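Working notes: capping the ring amine of compound 1

The source may hold more compounds than are shown below. What is called first, only, known or untested is meant among the compounds shown, and "the series" means these compounds.

Three compounds have numbers in a physicochemical assay for lipophilicity, using the shake flask method, measured as octanol-water partition, at pH 7.4; a lower number here means a more polar compound, a higher number a more lipophilic compound. Compound 1 `CC(C)n1cc(-c2ccnc3[nH]c(C4CCNCC4)cc23)ccc1=O` gives -0.2, the lowest of the three. Compound 2 `CN(C)C(=O)CN1CCC(c2cc3c(-c4ccc(=O)n(C5CCOCC5)c4)ccnc3[nH]2)CC1` gives 1.1, higher than compound 1 beyond the scatter. Compound 3 `COc1cc(F)ccc1-c1ccnc2[nH]c(C3CCOCC3)cc12` gives 3.9, the furthest from compound 1 and again beyond the scatter. For the measured compounds named here, no two of these differ in a single place, so no measured step exists.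

Compound 4 `CC(C)n1cc(-c2ccnc3[nH]c(C4CCN(CC(=O)N5CCCCC5)CC4)cc23)ccc1=O` awaits measurement; it differs from compound 1 thus: ((piperidin-1-yl)carbonyl)methyl in place of hydrogen on an amine nitrogen in a ring. The step of a number 2.00 log units higher from compound 1 to compound 4 (beyond the scatter) is expected to be a rise beyond the scatter, because compound 2, which bears an amide-bearing methyl group on the same ring nitrogen, gives 1.1. Compound 4 is expected at 1.8, between 1 and 2.6.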

Compound 4, distribution coefficient: 2.8
The estimate for compound 4 lay 1.00 log units below the measured number; measured number above the stated range.
By their numbers in this assay, from the lowest: compound 1; then compound 2; then compound 4; then compound 3.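

Capping the ring amine is the first single-place change in the series that can be read: in this assay, ((piperidin-1-yl)carbonyl)methyl in place of hydrogen on this amine nitrogen in a ring gives a number 3.00 log units higher from compound 1 to compound 4 (beyond the scatter). The position is thus shown to carry a large shift in this read-out from one change. Nothing available accounts for the size of this step.

Which part of the entering group carries the shift stays open. A plain methyl or a carboxylic acid on the same nitrogen would bear on that question.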